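A few compounds are considered here, and "the series" means these few. Any claim that something is new, unique, unknown or untested is made for them only; others in the source may bear on it.

Compounds measured so far:

Compound 1, `CC(C)N1CCN(Cc2csc(N)c2C(=O)c2ccc(Cl)cc2)CC1`, gives -7.4% in a functional assay on CHO cells with adenosine receptor A1 (Homo sapiens) as the target, read by cAMP accumulation and immunoassay, with a stated time of 6 min, tested at 10 uM; a higher number here means a weaker effect of the compound at the concentration tested, a lower number a stronger effect.
Compound 2, `Nc1scc(CN2CCN(c3cccnc3)CC2)c1C(=O)c1ccc(Cl)cc1`, gives -23% in this assay.

Among the measured compounds shown here, compound 2 stands lowest of the two numbers so far in this assay, and its nearest neighbour is compound 1, which sits higher by a step that lies beyond the scatter. For the measured compounds named here, the one measured step, a number 15.6 percentage points lower from compound 1 to compound 2 (beyond the scatter), replaces a small group on the ring nitrogen by an aromatic ring, and it is the only step that bears on the change now considered.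

Compound 3, `Nc1scc(CN2CCN(c3cccc4ccccc34)CC2)c1C(=O)c1ccc(Cl)cc1`, differs from compound 2 in one place: naphthalen-1-yl in place of pyridin-3-yl on an amine nitrogen in a ring. Here one aromatic group on that ring nitrogen gives way to another, larger one, so the step from compound 1 to compound 2 is only a loose guide: it shows that an aromatic group in this place can move the number down, but it does not show what a second such group does. Going by the values given here, no measured pair exchanges one aromatic group for another on this nitrogen.

The expectation is therefore a step of a number 3 percentage points higher from compound 2 to compound 3 (within the scatter) in this assay, which is within the scatter. Compound 3 is estimated at -20%, with a range from -45% to 5%.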

Compound 3, a percentage reported as activity, at one concentration (the size of the read-out at that concentration, not a potency): -21%
The estimate for compound 3 lay 1 percentage points above the measured number; measured number inside the range.
By their numbers in this assay, from the lowest: compounds 2 and 3 (each within the scatter of the next); then compound 1.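

In this assay, among the compounds shown here, the exchange of pyridin-3-yl for naphthalen-1-yl gives a number 2 percentage points higher from compound 2 to compound 3 (within the scatter), the first measured exchange of one aromatic group for another on this ring nitrogen. A single six-membered aromatic ring with a hetero atom and two six-membered aromatic rings of carbon only thus cannot be told apart at this position in this assay, despite the difference in heavy atoms between them. Against the isopropyl group of compound 1, naphthalen-1-yl gives a number 13.6 percentage points lower from compound 1 to compound 3 (beyond the scatter), so the earlier lowering of the number with an aromatic group on this nitrogen now holds for two different aromatic groups, and nothing in the data shown explains this result.

The step from compound 2 to compound 3 changes ring size and the ring nitrogen together, so phenyl on this nitrogen would be needed to take these two changes apart. From the compounds shown here alone, it also remains open whether a non-aromatic ring such as cyclohexyl, or an aromatic group carrying a carboxylic acid or an amine, would give a number in line with compound 2 and compound 3 or with compound 1.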